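The source may hold more compounds than are shown below. What is called first, only, known or untested is meant among the compounds shown, and "the series" means these compounds.

Compound 3 `Cc1nnc(SCC(=O)N/N=c2/scc(-c3ccc(C#N)cc3)n2-c2ccccc2)s1` and compound 4 `Cc1ccc(-c2cs/c(=N/NC(=O)CSc3nnc(C)s3)n2-c2ccccc2)cc1` share one core with compound 1 `Cc1ccc(-c2cs/c(=N/NC(=O)CSc3nnnn3-c3ccccc3)n2-c2ccccc2)cc1` and compound 2 `Cc1ccc(-c2cs/c(=N/NC(=O)CSc3nncn3C)n2-c2ccccc2)cc1`, and they are compared in an ADME assay on NIH3T3 cells (Mus musculus) for cytotoxicity, read by MTT assay, with a stated time of 24 h; on this read-out lower numbers stand for stronger inhibition and higher numbers for weaker inhibition. In this assay compound 1 gives > 500 ug/mL, which is a limit of the assay and not a number, as the limit of > 500 ug/mL in this assay, at which 1 of the 3 values shown sits, records. Compound 2 gives 130 ug/mL in this assay, so there is an at least 3.8-fold lower number from compound 1 to compound 2 (0.58 log units; beyond the scatter). In this assay, for the measured compounds named here, compound 3 gives < 3.9 ug/mL, again only a limit, as the limit of < 3.9 ug/mL in this assay, at which 1 of the 3 values shown sits, records; of the three values so far, two are limits, and compound 3 stands at the lower one, without a number of its own.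

The change from compound 3 to compound 4 is methyl in place of cyano on an aromatic carbon, or, cut one bond further out, 4-cyanophenyl to 4-methylphenyl. Going by the values given here, no measured step touches this position: the single measured step, from compound 1 to compound 2, alters the group on the sulfur and leaves the methylphenyl in place. Compound 4 carries the methylphenyl of compounds 1 and 2 together with the sulfur-bound group of compound 3, so the expected step in this assay is an at least 7.6-fold higher number from compound 3 to compound 4 (0.88 log units; beyond the scatter), toward a higher number. Compound 4 is therefore estimated at 30 ug/mL, within 5 ug/mL to 150 ug/mL.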

Compound 4, half-maximal inhibitory concentration: 373 ug/mL
Compound 4: middle estimate off by 12-fold (1.09 log units), on the low side, outside the stated range (above it).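

In this assay, the exchange of 4-cyanophenyl for 4-methylphenyl gives an at least 95-fold higher number from compound 3 to compound 4 (1.98 log units; beyond the scatter), the first step at this position and the only one of large size among the compounds shown; with the 5-methyl-1,3,4-thiadiazol-2-yl group held fixed on the sulfur, the low number of compound 3 therefore goes with the cyano compound of this pair and not with that sulfur-bound group alone. The size of this step is only a floor, as compound 3 has a limit and not a number: the limit of < 3.9 ug/mL in this assay, at which 1 of the 4 values shown sits. With the methylphenyl held fixed, changing the group on the sulfur moves the number much less, with a 2.9-fold higher number from compound 2 to compound 4 (0.46 log units; beyond the scatter), while an at least 1.3-fold lower number from compound 1 to compound 4 (0.12 log units; that floor lies within the scatter) leaves compound 1 and compound 4 unseparated.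

Going by these compounds, the position rests on this single pair, so it remains open whether the same step would appear with the 4-methyl-4H-1,2,4-triazol-3-yl or 1-phenyl-1H-tetrazol-5-yl group on the sulfur. On these data alone, it is also open where an amine or a carboxylic acid on that aromatic carbon would fall relative to the cyano and methyl compounds.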